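A few compounds are considered here, and "the series" means these few. Any claim that something is new, unique, unknown or untested is made for them only; others in the source may bear on it.

Working notes on the series. Three compounds carry numbers in a functional assay on K562 cells (Homo sapiens) for inhibition, read by trypan blue exclusion, with a stated time of 72 h (on this read-out lower numbers stand for stronger inhibition and higher numbers for weaker inhibition), so far. Compound 1 `Cn1c(=O)c(S(=O)(=O)c2ccc(Cl)cc2)cc2cnc(Nc3cnc4ccccc4c3)nc21` gives 15000 nM. Compound 3 `Cc1ccc(S(=O)(=O)c2cc3cnc(Nc4cccc5cccnc45)nc3n(C)c2=O)cc1` gives 10000 nM. Compound 2 `O=c1c(S(=O)(=O)c2ccc(F)cc2F)cc2cnc(Nc3ccc4[nH]ccc4c3)nc2n1C1CC1` gives 500 nM, the lowest number of the three; its gap to compound 3 is beyond the usual scatter, and its gap to compound 1 is wider still, so compound 2 is the most potent compound measured.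

The next compound, compound 4 `O=c1c(S(=O)(=O)c2ccc(F)cc2F)cc2cnc(Nc3ccc4[nH]ccc4c3)nc2n1CC1CC1`, keeps the whole of compound 2 apart from one change: cyclopropylmethyl in place of cyclopropyl on an aromatic nitrogen. Going by the values given here, no pair of measured compounds differs in one place, so there is no measured step to lean on for this change.

Among the compounds with values here, with only the one-carbon lengthening at the aromatic nitrogen, and no comparable step in hand, the expected step from compound 2 to compound 4 in this assay is small, most likely none beyond the scatter, with a slight lean towards a higher number: a 1.4-fold higher number from compound 2 to compound 4 (0.15 log units; within the scatter). Compound 4 is therefore estimated at 700 nM in this assay, within a range from 250 nM to 2500 nM.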

Compound 4, half-maximal inhibitory concentration: 1000 nM
For compound 4 the middle estimate is 1.4-fold (0.15 log units) below the measured one; the measured number falls inside the stated range.
By their numbers in this assay, from the lowest: compounds 2 and 4 (each within the scatter of the next); then compounds 3 and 1 (each within the scatter of the next).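

Going by these compounds alone, the step at this aromatic nitrogen is the first comparison that differs in one place: in this assay, cyclopropylmethyl in place of cyclopropyl gives a 2.0-fold higher number from compound 2 to compound 4 (0.30 log units; within the scatter). The position therefore takes this swap with no change that can be told from the scatter, though the reading covers these two groups only, both of which carry the same three-membered non-aromatic ring of carbon only. Nothing at hand bears on the reason for the size of this step.

As far as these compounds go, it remains open whether a group at this nitrogen without that ring, such as a longer chain like n-butyl or a chain ending in an amine, would stay as close to compound 2. Within the data shown here, compounds 1 and 3 differ from compound 2 in more than one place, so no step to either can be read.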